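The source may report more compounds than this note shows. Statements on the series, on what has been measured and on what is new or still open speak of the compounds shown alone.

Measured so far in a functional assay on NCI-H520 cells (Homo sapiens) for cytotoxicity; on this read-out higher numbers stand for weaker inhibition of growth and lower numbers for stronger inhibition of growth:
- compound 1 `COc1ccc(C2=C(c3ccc(SC)cc3)CC3CCCN3C2=O)cc1OC(=O)CNC(=O)OC(C)(C)C`: 7000 nM
- compound 2 `COc1ccc(C2=C(c3ccc(SC)cc3)CC3CCCN3C2=O)cc1OC`: 2000 nM

Compound 1 has the higher of these two numbers, so it inhibits growth less strongly than compound 2. Compound 3 `COc1ccc(C2=C(c3ccc(SC)cc3)CC3CCCN3C2=O)cc1` differs from compound 1 by a hydrogen atom in place of a group of 12 heavy atoms (7 carbon, 1 nitrogen, 4 oxygen; no ring), on an aromatic carbon, ortho to a methoxy group. Going by the values given here, one measured step bears on this: a 3.5-fold lower number from compound 1 to compound 2 (0.54 log units; beyond the scatter). There the same large group leaves, but a methyl remains on the oxygen, so this step is only an imperfect guide. In this assay, a similar drop is therefore expected. The expected step is a 2.8-fold lower number from compound 1 to compound 3 (0.45 log units; beyond the scatter). The estimate for compound 3 is 2500 nM, with an expected range from 800 nM to 7000 nM.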

Compound 3, concentration for 50% growth inhibition: 800 nM
Compound 3: the middle estimate sits 3.1-fold (0.49 log units) above what was measured; measured number inside the range.
By their numbers in this assay, from the lowest: compound 3; then compound 2; then compound 1.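

In this assay, replacing the large group with hydrogen lowers the number further than replacing it with methoxy (an 8.8-fold lower number from compound 1 to compound 3 (0.94 log units; beyond the scatter)), and swapping methoxy for hydrogen lowers it again (a 2.5-fold lower number from compound 2 to compound 3 (0.40 log units; beyond the scatter)). Across these three compounds, the number falls as the group on this aromatic carbon gets smaller, none goes against this trend, and growth inhibition here does not need an oxygen on this carbon. Nothing available explains why the number falls. On these data alone, it remains open whether a fluorine atom, an amine or a hydroxyl group on this carbon would match hydrogen or give a lower number still.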